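Changing the amide side chain of compound 2

The source may report more compounds than this note shows. Statements on the series, on what has been measured and on what is new or still open speak of the compounds shown alone.

Of the compounds shown here, two with a shared core have been measured so far. Going by the values given here, in an ADME assay on the whole organism (plasma, strain CD) for pharmacokinetics, with Rattus norvegicus as the target, at a dose of 5 mg/kg by the oral route (a lower number here means less compound in the circulation, a higher number more compound in the circulation at the dose given), compound 1 `Cn1c(=O)c(C(=O)NCCO)c(O)c2ncc(Cc3ccc(F)cc3)cc21` gives 22800 ng.h/mL and compound 2 `C[C@@H](CO)CNC(=O)c1c(O)c2ncc(Cc3ccc(F)cc3)cc2n(C)c1=O` gives 12600 ng.h/mL, so compound 2 stands within the usual scatter of its only neighbour. Compound 3 `COCCNC(=O)c1c(O)c2ncc(Cc3ccc(F)cc3)cc2n(C)c1=O` keeps the core and carries methoxymethyl in place of 1-(hydroxymethyl)ethyl on a saturated chain carbon bound to an amide-type nitrogen. Among the compounds with values here, one measured step bears on this change: a 1.8-fold lower number from compound 1 to compound 2 (0.26 log units; within the scatter), made at the same place, stays within the scatter. Within the data shown here, no measured compound carries methoxymethyl there, so this single step is only a loose guide. The expected step is a 1.2-fold higher number from compound 2 to compound 3 (0.08 log units; within the scatter), with nothing expected beyond the scatter. For compound 3 the estimate is 15000 ng.h/mL, with an expected range from 6000 ng.h/mL to 35000 ng.h/mL.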

Compound 3, area under the concentration-time curve: 1850 ng.h/mL
Estimate against measurement, compound 3: 8.1-fold (0.91 log units) above, outside the stated range (below it).
By their numbers in this assay, from the lowest: compound 3; then compounds 2 and 1 (each within the scatter of the next).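

In this assay, this position proves sensitive to what sits at the end of the amide side chain. The two side chains ending in a free hydroxyl lie within the scatter of each other, yet 2-methoxyethyl gives a 6.8-fold lower number from compound 2 to compound 3 (0.83 log units; beyond the scatter), and the cleanest comparison, where only a methyl is added on the oxygen, gives a 12-fold lower number from compound 1 to compound 3 (1.09 log units; beyond the scatter). Nothing measured here shows what lies behind this fall.

Going by these compounds, it remains open whether the fall is specific to the methyl on that oxygen or would also follow if an amine or a carboxylic acid ended the chain. The compounds shown also leave open how a longer chain ending in a hydroxyl would behave.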